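Triazole to aminothiazole on the sulfur-linked methylene

The source may report more compounds than this note shows. Statements on the series, on what has been measured and on what is new or still open speak of the compounds shown alone.

Compound 2 `N#Cc1c(N)nc(SCn2cncn2)c(C#N)c1-c1ccc(OCC2CC2)cc1` is the lower of the two measured compounds: in an assay on CHO cells for displacement of a labelled ligand from adenosine receptor A3 (Homo sapiens), read by scintillation counting, with a stated time of 120 min, tested at 1 uM (on this read-out lower numbers stand for less inhibition and higher numbers for more inhibition at the one concentration tested (going by the name of the read-out)), compound 2 gives 1%, while compound 1 `N#Cc1c(N)nc(SCc2cccnc2)c(C#N)c1-c1ccc(OCC2CC2)cc1` gives 19%. Going by the values given here, the single recorded step, a number 18 percentage points lower from compound 1 to compound 2 (beyond the scatter), is the only one touching the ring on the saturated chain carbon bound to a sulfur. Compound 3 `N#Cc1c(N)nc(SCc2csc(N)n2)c(C#N)c1-c1ccc(OCC2CC2)cc1` carries the change 2-amino-1,3-thiazol-4-yl in place of 1H-1,2,4-triazol-1-yl on a saturated chain carbon bound to a sulfur at that same place. Because the change from compound 1 to compound 2 moved the number by a number 18 percentage points lower from compound 1 to compound 2 (beyond the scatter), a swap of the ring here can shift the read-out by roughly that size; in which direction compound 3 goes is not shown by any measured pair. The step is therefore expected to be small, around a number 9 percentage points higher from compound 2 to compound 3 (within the scatter), and compound 3 is estimated at 10%, within 0% to 30%.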

Compound 3, a percentage reported as inhibition, at one concentration (the size of the read-out at that concentration, not a potency): 1%
The estimate for compound 3 lay 9 percentage points above the measured number, and the stated range covers the measured number.
By their numbers in this assay, from the lowest: compounds 2 and 3 (each within the scatter of the next); then compound 1.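

In this assay, placing 2-amino-1,3-thiazol-4-yl in place of 1H-1,2,4-triazol-1-yl on a saturated chain carbon bound to a sulfur gives no change at the digits printed from compound 2 to compound 3 (within the scatter) and so shows that the two five-membered aromatic rings cannot be told apart at this place, despite the hydrogen-bond donor and the sulfur that enter. Against pyridin-3-yl, the aminothiazole gives a number 18 percentage points lower from compound 1 to compound 3 (beyond the scatter) in the same direction as the triazole, so among these three compounds the pyridin-3-yl compound stands alone at the higher number. No evidence bearing on the reason for this is available.

From the compounds shown here alone, whether a phenyl ring or pyridin-4-yl at this place would match or exceed compound 1 remains open. So does the outcome with a carboxylic acid or a longer alkyl chain on the saturated chain carbon bound to a sulfur.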